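This account rests on a few compounds, and the source may have more. Where it says the series, first, only, none or still open, it means among the compounds named here.

Compound 1 `Cc1cc(S(=O)(=O)Nc2nc3cscc3c(=O)n2Cc2ccccc2)c(S)cc1Cl` and compound 2 `Cc1cc(S(=O)(=O)Nc2nc3ccsc3c(=O)n2Cc2ccccc2)c(S)cc1Cl` share one core and differ only in how the two fused rings are joined. In a functional assay on NCI-H322M cells (Homo sapiens) for inhibition (a higher number here means a weaker inhibitor of growth, a lower number a stronger inhibitor of growth), compound 1 gives 18200 nM and compound 2 gives 19500 nM; compound 2 holds the higher of the two numbers, yet the gap to compound 1 lies within the scatter, so the two are not distinguished. Compound 3 `Cc1cc(S(=O)(=O)Nc2nc3cc(-c4ccccc4)sc3c(=O)n2Cc2ccccc2)c(S)cc1Cl` carries phenyl in place of hydrogen on an aromatic carbon. Going by the values given here, no measured pair shows what this change does, so the direction is open; the expected step from compound 2 to compound 3 is a 1.3-fold lower number from compound 2 to compound 3 (0.11 log units; within the scatter), a small one. For compound 3 the estimate in this assay is 15000 nM, ranging from 5000 nM to 45000 nM.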

Compound 3, concentration for 50% growth inhibition: > 100000 nM
Compound 3 ended at the assay's limit (the forecaster's own chance of this, stated with the estimate: 10%); at least 6.6-fold (0.82 log units) between middle value and limit.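

Compounds 1 and 2 could not be told apart, but this change at the shared core does separate two compounds. Phenyl in place of hydrogen on the aromatic carbon next to the ring sulfur gives an at least 5.1-fold higher number from compound 2 to compound 3 (0.70 log units; beyond the scatter) in this assay, so growth inhibition is lost at this position. On these data alone, compound 3 gives > 100000 nM, which is a limit of the assay and not a number, so the full size of the loss stays unknown. As far as these compounds go, whether the loss belongs to phenyl alone or to any group on this carbon remains open. A methyl group or an amine there would help to tell these apart.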